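Aminophenyl for methylphenyl on a shared kinase-binding core

The compounds below may be only part of what the source reports. "The series", "measured", "known", "first", "only" and "open" are said of these compounds alone.

Compound 1: `CCCS(=O)(=O)Nc1ccc(F)c(C(=O)c2n[nH]c3ncc(-c4ccccc4Cl)cc23)c1F`, 9.3%
Compound 2: `CCCS(=O)(=O)Nc1ccc(F)c(C(=O)c2n[nH]c3ncc(-c4cccc(C)c4)cc23)c1F`, 15%

Of the compounds shown here, two have been measured in an assay for binding affinity to dual specificity mitogen-activated protein kinase kinase 4 (Homo sapiens), read by KINOMEscan, tested at 100 nM; a lower number here means a stronger effect, a higher number a weaker effect of the compound at the concentration tested. Compound 1 gives 9.3%, and compound 2 gives 15%. For the measured compounds named here, the one measured step, a number 5.7 percentage points higher from compound 1 to compound 2 (within the scatter), lies within the scatter, so the two compounds cannot be ordered; compound 2 simply stands with the higher of the two numbers, its nearest neighbour being compound 1.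

Compound 3 is `CCCS(=O)(=O)Nc1ccc(F)c(C(=O)c2n[nH]c3ncc(-c4ccc(N)cc4)cc23)c1F`. It differs from compound 2 in one place: 4-aminophenyl in place of 3-methylphenyl on an aromatic carbon. Going by the values given here, no measured step shows what a 4-aminophenyl group does on this position; the only step available, from 2-chlorophenyl to 3-methylphenyl, stayed within the scatter. On that basis the expectation for compound 3 is a step of about a number 1 percentage points lower from compound 2 to compound 3 (within the scatter), that is, no change beyond the scatter, with a wide range to allow for the untested group. In this assay compound 3 is therefore estimated at 14%, with a range from 4% to 40%.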

Compound 3, a percentage reported as activity, at one concentration (the size of the read-out at that concentration, not a potency): 0.1%
For compound 3 the middle estimate is 13.9 percentage points above the measured one; the measured number lies below the stated range.
By their numbers in this assay, from the lowest: compounds 3, 1 and 2 (each within the scatter of the next, the first and the last beyond it).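

The shared core gives its first change beyond the scatter in this assay: the step is a number 14.9 percentage points lower from compound 2 to compound 3 (beyond the scatter) and shows that the group placed here can move the read-out, which the earlier pair of compounds did not show. That separation is not general, since the other step involving the same group is a number 9.2 percentage points lower from compound 1 to compound 3 (within the scatter) and leaves compound 3 and compound 1 without an order, so 4-aminophenyl stands apart from 3-methylphenyl but not from 2-chlorophenyl. The compounds shown offer no measurement that accounts for the step from 3-methylphenyl.

On these data alone, what remains open is whether the amine itself or its place on the phenyl ring goes with the step, as the group and its place differ together between compound 2 and compound 3. A 3-aminophenyl or a 4-methylphenyl group would separate the two, while a plain phenyl group or a 4-hydroxyphenyl group would show how the amine compares with a hydrogen or a hydroxyl on the same carbon.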